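From 3,4-dimethoxyphenyl to 2-chlorophenyl: a small expected step

This account rests on a few compounds, and the source may have more. Where it says the series, first, only, none or still open, it means among the compounds named here.

In a functional assay on DU-145 cells (Homo sapiens) for cytotoxicity, read by sulforhodamine B assay, with a stated time of 48 h (on this read-out higher numbers stand for weaker inhibition and lower numbers for stronger inhibition), compound 1 (`C[C@H]1CC[C@@H]2[C@@H](OC(=O)[C@]23CC(c2ccc(Cl)cc2)=NO3)[C@]2(C)C(=O)C=C[C@@]12O`) gives 43000 nM and compound 2 (`C[C@H]1CC[C@@H]2[C@@H](OC(=O)[C@]23CC(c2ccccc2)=NO3)[C@]2(C)C(=O)C=C[C@@]12O`) gives 39800 nM with a 1.1-fold lower number from compound 1 to compound 2 (0.03 log units; within the scatter) separating them. Compound 3 (`COc1ccc(C2=NO[C@]3(C2)C(=O)O[C@@H]2[C@H]3CC[C@H](C)[C@]3(O)C=CC(=O)[C@@]23C)cc1OC`) gives 84000 nM as the highest of these three numbers, with a 2.0-fold higher number from compound 1 to compound 3 (0.29 log units; within the scatter) and a 2.1-fold higher number from compound 2 to compound 3 (0.32 log units; beyond the scatter) leading to it. Compound 4 (`C[C@H]1CC[C@@H]2[C@@H](OC(=O)[C@]23CC(c2ccccc2Cl)=NO3)[C@]2(C)C(=O)C=C[C@@]12O`) has 2-chlorophenyl in place of 3,4-dimethoxyphenyl (2-chlorophenyl in place of 3,4-dimethoxyphenyl on a carbon with a double bond to nitrogen). Within the data shown here, no measured compound carries 2-chlorophenyl, so the nearest guides are compound 1 and compound 2, which lack the dimethoxy groups. Those two steps to compound 3 are small, so only a small drop is expected. In this assay the expected change is a 2.0-fold lower number from compound 3 to compound 4 (0.30 log units; within the scatter) with its direction taken from those steps. Compound 4 is estimated at 42000 nM with 20000 nM to 85000 nM as its expected range.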

Compound 4, half-maximal inhibitory concentration: 19000 nM
Compound 4: middle estimate off by 2.2-fold (0.34 log units), on the high side; measured number below the stated range.
By their numbers in this assay, from the lowest: compound 4; then compounds 2, 1 and 3 (each within the scatter of the next, the first and the last beyond it).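

In this assay, a chloro group on the phenyl ring now makes a difference beyond the scatter: a 2.1-fold lower number from compound 2 to compound 4 (0.32 log units; beyond the scatter), whereas compound 1 and compound 2 lay within the scatter of each other. Keeping the chloro group but changing 4-chlorophenyl to 2-chlorophenyl gives a 2.3-fold lower number from compound 1 to compound 4 (0.35 log units; beyond the scatter), so its place on the ring matters, and the whole change gives a 4.4-fold lower number from compound 3 to compound 4 (0.65 log units; beyond the scatter). Nothing measured here explains these differences. Going by these compounds, whether chloro itself is needed remains open, since a fluoro or methyl group in place of the chloro of 2-chlorophenyl could tell.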